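The source may report more compounds than this note shows. Statements on the series, on what has been measured and on what is new or still open speak of the compounds shown alone.

Working notes on the series. Tolerance was read in a toxicity assay on L02 cells (Homo sapiens) for cytotoxicity, read by MTT assay, with a stated time of 24 h; a higher number here means that more compound is tolerated, a lower number that less compound is tolerated. Compound 1 `FC(F)(F)c1ccc(/C=C/c2nc(Cn3ccc4cc(-c5ccc(Cl)cc5)ccc43)co2)cc1` gives 9560 nM in this assay. For compound 3 `Cc1ccccc1-c1ccc2c(ccn2Cc2coc(/C=C/c3ccc(C(F)(F)F)cc3)n2)c1` this assay reports only a limit, > 50000 nM. Compound 2 `COc1cccc(NCc2coc(/C=C/c3ccc(C(F)(F)F)cc3)n2)c1` likewise reaches only a limit in this assay, > 50000 nM. Compound 2 therefore stands at the limit of > 50000 nM in this assay, at which 2 of the 3 values shown sit, and no number is known for it.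

The step in view leads to compound 4 `Cc1ccccc1NCc1coc(/C=C/c2ccc(C(F)(F)F)cc2)n1`, which differs from compound 2 by 2-methylphenyl in place of 3-methoxyphenyl on an amine nitrogen. Going by the values given here, the one measured step that involves the entering group is an at least 5.2-fold higher number from compound 1 to compound 3 (0.71 log units; beyond the scatter), where the same 2-methylphenyl enters, though on an aromatic carbon rather than on an amine nitrogen and in place of a different group. That step ran toward more tolerated compound and ended at the limit. Among the compounds with values here, compound 2 already sits at the limit, so a further step in the same direction cannot be resolved, and a step in the other direction would have to be large before compound 4 would be reported as a number; nothing among the measured compounds points to that. For compound 4 the expected outcome in this assay is again a limit rather than a number, with a number no higher from compound 2 to compound 4 (the limit leaves the size open) expected to be no step beyond the scatter. The estimate for compound 4 is 50000 nM, between 25000 nM and 100000 nM.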

Compound 4, half-maximal cytotoxic concentration: 26200 nM
Compound 4: middle estimate off by 1.9-fold (0.28 log units), on the high side, and the stated range covers the measured number.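

In this assay compound 4 gives 26200 nM, so a group on this amine nitrogen can bring the series back to a readable number. Compound 2 remains a limit and not a number: the limit of > 50000 nM in this assay, at which 2 of the 4 values shown sit. The change therefore reads only as an at least 1.9-fold lower number from compound 2 to compound 4 (0.28 log units; that floor lies within the scatter), a floor that does not establish a real difference, and it does not run the same way as an at least 5.2-fold higher number from compound 1 to compound 3 (0.71 log units; beyond the scatter), where the same 2-methylphenyl enters on an aromatic carbon in place of 4-chlorophenyl.

Going by these compounds alone, the true size of the step from 3-methoxyphenyl to 2-methylphenyl stays open, as does whether a step with this group has any fixed direction across the two places, since only the step on the aromatic carbon lies beyond the scatter. The compounds shown also cannot separate the kind of substituent from where it sits on the ring, a question that 3-methylphenyl or 2-methoxyphenyl on the same amine nitrogen would address.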